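Carboxy in Place of Fluoro: an Expected Cytotoxicity Outcome

The compounds below may be only part of what the source reports. "The series", "measured", "known", "first", "only" and "open" are said of these compounds alone.

Compound 1 `Cc1cc(NC(=O)Nc2ccc(F)cc2)c2ccccc2n1` was tested in an ADME assay on HepG2 cells (Homo sapiens) for cytotoxicity, with a stated time of 72 h; on this read-out lower numbers stand for an effect already at smaller amounts and higher numbers for an effect only at larger amounts of compound. There compound 1 gives > 25000 nM, which is a limit of the assay and not a number. Compound 2 `Cc1cc(NC(=O)Nc2ccc(F)cc2F)c2ccccc2n1` gives 17000 nM, and the step is an at least 1.4-fold lower number from compound 1 to compound 2 (0.16 log units; that floor lies within the scatter). Compound 3 `Cc1cc(NC(=O)Nc2ncccc2C)c2ccccc2n1` gives > 25000 nM, again a limit. Accordingly the step that the two limits leave unreadable from compound 1 to compound 3. Two of the three values sit at the limit of > 25000 nM in this assay, at which 2 of the 3 values shown sit. Compound 4 `Cc1cc(NC(=O)Nc2ccc(C(=O)O)cc2)c2ccccc2n1` differs from compound 1 by carboxy in place of fluoro on an aromatic carbon. Among the compounds with values here, no measured step exchanges fluoro for carboxy, and the one readable step, fluoro in place of hydrogen, lay within the scatter. For compound 4 the expected step is therefore a step that the limit leaves unreadable from compound 1 to compound 4, nothing beyond the scatter. Compound 4 is estimated at 30000 nM, between 15000 nM and 80000 nM.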

Compound 4, half-maximal effective concentration: > 25000 nM
Compound 4 ended at the assay's limit; the forecaster's own chance of this, stated with the estimate: 85%; the middle value is on the limit's open side.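

Compound 1 and compound 4 both end at a limit in this assay, not at a number, so the step between them cannot be read: the limit of > 25000 nM in this assay, at which 3 of the 4 values shown sit.

The compounds shown leave open whether carboxy in place of fluoro changes this read-out at all.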